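The compounds below may be only part of what the source reports. "The series", "measured", "known", "first", "only" and "open" are said of these compounds alone.

The series shares the core seen in compound 1 `O=C(COc1ccc(C(=O)/C=C/c2ccc(F)cc2)cc1)N[C@H]1CCOC1=O`. In a functional assay on DU-145 cells (Homo sapiens) for antiproliferative activity, read by MTT assay, with a stated time of 72 h (on this read-out higher numbers stand for weaker inhibition and lower numbers for stronger inhibition), compound 1 gives 18800 nM. Compound 2 `CC(C)c1ccc(NCC(=O)N[C@H]2CCOC2=O)cc1` is an anilino member of the set. In this assay compound 2 returns only a limit of the assay, > 64000 nM. Compound 3 `O=C(CNc1ccccc1F)N[C@H]1CCOC1=O` is the second anilino member. In this assay compound 3 likewise returns only a limit, > 64000 nM, so no number is known for it. Among the compounds with values here, compound 1 is the only member with a numerical value; two of the three values shown sit at the limit (the limit of > 64000 nM in this assay, at which 2 of the 3 values shown sit). Compound 4 `O=C(CNc1ccccc1)N[C@H]1CCOC1=O` is not yet measured. The change from compound 3 to compound 4 is hydrogen in place of fluoro on an aromatic carbon. Within the data shown here, no step between measured compounds is available, so no measured size for this kind of change exists. The expected step that the limit leaves unreadable from compound 3 to compound 4 is an estimate set against a limit, with no move beyond the scatter anticipated. Compound 4 is expected at 90000 nM, within a range from 30000 nM to 300000 nM, and most probably reported again only as a limit.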

Compound 4, half-maximal inhibitory concentration: > 64000 nM
Compound 4: only a limit was reported (the forecaster's own chance of this, stated with the estimate: 80%); the middle value is on the limit's open side.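

Compound 4 returns only a limit, > 64000 nM, so the steps to it from compound 3 and from compound 2 cannot be read: the limit of > 64000 nM in this assay, at which 3 of the 4 values shown sit.

From the compounds shown here alone, whether hydrogen, fluoro or isopropyl on an aromatic carbon makes any difference among the anilino members stays open, with no numerical value for compound 2, compound 3 or compound 4.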